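The source may report more compounds than this note shows. Statements on the series, on what has been measured and on what is new or still open speak of the compounds shown alone.

Three compounds share one core and differ around it: compound 1 `Cc1ccccc1NC(=O)N[C@H](C)c1ccccc1`, compound 2 `Cc1ccccc1NC(=O)N[C@@H](C)c1ccccc1` and compound 3 `CC(C)c1ccccc1NC(=O)N[C@@H](C)c1ccccc1`. In an ADME assay on the whole organism with Oryza sativa as the target, tested at 1 uM (on this read-out lower numbers stand for a stronger effect and higher numbers for a weaker effect at the one concentration tested), compound 1 gives 100%, compound 2 gives 99% and compound 3 gives 96%. Compound 2 sits between the other two, and neither gap is a real one: the step of a number 1 percentage points lower from compound 1 to compound 2 (within the scatter) rests on (the fact that compounds 1 and 2 differ only in the configuration as drawn), and the step of a number 3 percentage points lower from compound 2 to compound 3 (within the scatter), with isopropyl in place of methyl on an aromatic carbon, also stays inside the scatter. All three numbers thus describe a weak effect at the one concentration tested.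

Compound 4 `Cc1cc(F)ccc1NC(=O)N[C@@H](C)c1ccccc1` is not yet measured. It differs from compound 2 by fluoro in place of hydrogen on an aromatic carbon. Going by the values given here, no measured step introduces a fluoro, so the only guidance is indirect: a change of configuration and a change of an aromatic substituent have both left this assay unmoved, so compound 4 is expected to show a number 2 percentage points lower from compound 2 to compound 4 (within the scatter), that is, no step beyond the scatter. On that basis the value of compound 4 in this assay is estimated at 97%, with a likely range from 86% to 100%.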

Compound 4, a percentage reported as activity, at one concentration (the size of the read-out at that concentration, not a potency): 98%
Beside the measured number, compound 4's estimate is 1 percentage points below it; the range from low to high includes it.
By their numbers in this assay, from the lowest: compounds 3, 4, 2 and 1 (each within the scatter of the next).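

In this assay, fluoro in place of hydrogen on an aromatic carbon, meta to a methyl group and para to a large group, gives a number 1 percentage points lower from compound 2 to compound 4 (within the scatter). Going by these compounds alone, this shows that a carbon of the aromatic ring that carries only hydrogen in the earlier compounds can take a fluoro without a step beyond the scatter, whereas the earlier steps touched only a configuration and the group already present as methyl, and compound 4, like those compounds, still describes a weak effect at the one concentration tested. Nothing available on these compounds speaks to why the fluoro change gives so small a step.

The compounds shown leave open whether a methoxy, a trifluoromethyl, an amine or a carboxylic acid on this same carbon would also stay within the scatter of compound 2, or whether any group here could move the read-out at all. With every number read at one concentration and all of them close together, they also leave open how these changes would look on a compound with a stronger effect.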